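Lengthening the Amide Chain: From Compound 3 to Compound 4

The compounds below may be only part of what the source reports. "The series", "measured", "known", "first", "only" and "open" are said of these compounds alone.

Compound 1, `CNC(=O)CC1CCc2cc(OC)c(OC)cc21`: 21.2%
Compound 2, `COc1cc2c(cc1OC)C(CC(=O)N(C)C)CC2`: 22.6%
Compound 3, `CCCCNC(=O)CC1CCc2cc(OC)c(OC)cc21`: 39.4%

These three compounds share one core and differ only in what sits on the amide. In a functional assay on the whole organism (strain Swiss albino) for inhibition, with Mus musculus as the target, in the writhing test, with stated times of 60 min and 15 min, at a dose of 100 mg/kg by the oral route (a lower number here means less inhibition, a higher number more inhibition at the dose given (going by the name of the read-out)), compound 3 stands highest of the three numbers. The gap a number 16.8 percentage points higher from compound 2 to compound 3 (beyond the scatter) and the gap a number 18.2 percentage points higher from compound 1 to compound 3 (beyond the scatter) both lie beyond the scatter, whereas a number 1.4 percentage points higher from compound 1 to compound 2 (within the scatter) lies within it, so compounds 1 and 2 cannot be put in order.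

Compound 4, `CCCCCNC(=O)CC1CCc2cc(OC)c(OC)cc21`, carries a single change relative to compound 3: methyl in place of hydrogen on a saturated chain carbon, four bonds along the chain from an amide-type nitrogen. Among the measured compounds shown here, the one step that speaks to this change is a number 18.2 percentage points higher from compound 1 to compound 3 (beyond the scatter), in which the saturated chain on the amide nitrogen was built up and inhibition rose modestly. The step of a number 1.4 percentage points higher from compound 1 to compound 2 (within the scatter) shows that a lone methyl added to the amide nitrogen did not move the number beyond the scatter. Adding one methyl to a chain that already exists is a smaller change than building that chain, so a step of modest size at most is expected, upward if anything, or none beyond the scatter: a number 3.6 percentage points higher from compound 3 to compound 4 (within the scatter). On that basis compound 4 is expected to give about 43%, with a range from 31% to 55%.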

Compound 4, a percentage reported as inhibition, in the whole organism at one dose (the size of the read-out at that dose, not a potency): 71.7%
Beside the measured number, compound 4's estimate is 28.7 percentage points below it, outside the stated range (above it).
By their numbers in this assay, from the lowest: compounds 1 and 2 (each within the scatter of the next); then compound 3; then compound 4.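

In this assay, among the compounds shown here, the end of the amide chain matters much more than the earlier compounds suggested: a single methyl on a saturated chain carbon, four bonds along the chain from an amide-type nitrogen, gives a large step, a number 32.3 percentage points higher from compound 3 to compound 4 (beyond the scatter). Compound 4 also stands far from the two small amides, with butyl in place of hydrogen giving a number 50.5 percentage points higher from compound 1 to compound 4 (beyond the scatter) and pentylamino in place of dimethylamino giving a number 49.1 percentage points higher from compound 2 to compound 4 (beyond the scatter), so among these compounds the pentyl chain on the amide is the change that carries the number furthest. Nothing available explains why one added carbon has so large an effect.

Going by these compounds, it remains open whether the number keeps rising with a longer chain such as hexyl or octyl, or whether it falls again beyond pentyl. Also open, on these data alone, is whether the effect depends on a straight chain and on the amide hydrogen, which could be tested with a branched isopentyl group, a cyclopentyl ring, or a pentyl chain with a methyl on the same amide nitrogen.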